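Dropping the Methoxy Group From the Shared Core

The compounds below may be only part of what the source reports. "The series", "measured", "known", "first", "only" and "open" are said of these compounds alone.

compound 1 `CCNC(=O)NCC1CCc2c(OC)cccc2N1C`: 92%
compound 2 `CCNC(=O)NCC1CCc2c(cccc2OC)N1`: "not determined" (no result reported)

Compound 1 `CCNC(=O)NCC1CCc2c(OC)cccc2N1C` reaches 92% in a functional assay on CHO cells with melatonin receptor type 1A (Homo sapiens) as the target, read by GTPgammaS binding, with a stated time of 1 h; a lower number here means a smaller maximal response, a higher number a larger maximal response. For compound 2 `CCNC(=O)NCC1CCc2c(cccc2OC)N1`, built on the same core, the result in this assay is "not determined" (no result reported), so compound 2 stands without a number. Compound 3 `CCNC(=O)NCC1CCc2ccccc2N1` differs from compound 2 by hydrogen in place of methoxy on an aromatic carbon. Among the compounds with values here, no measured pair shows this change, so its size is unknown; with compound 1 giving 92% in this assay, a near-full response from the shared core seems plausible, and the step is expected to be small or none beyond the scatter. Compound 3 is accordingly expected to give 80%, between 50% and 100%.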

Compound 3, largest response reached (Emax), in percent of the reference or control that the assay uses: 30%
Beside the measured number, compound 3's estimate is 50 percentage points above it; measured number outside the range, below it.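

Within the data shown here, compound 2 has no number to set against compound 3, so no step between them can be read. The compounds shown leave open what replacing methoxy with hydrogen does in this assay on this core. No evidence at hand bears on the result.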